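A Methyl in Place of Hydrogen on Compound 1

A few compounds are considered here, and "the series" means these few. Any claim that something is new, unique, unknown or untested is made for them only; others in the source may bear on it.

Compound 1 `Nc1n[nH]c(N)c1/N=N/c1ccncc1`: 17000 nM
Compound 2 `Nc1nn(C(=O)c2ccc([N+](=O)[O-])cc2)c(N)c1/N=N/c1ccc(O)cc1`: > 25000 nM (a limit)

For the measured compounds named here, in a functional assay on K562 cells (Homo sapiens) for cytotoxicity, read by fluorescence, with a stated time of 72 h (a higher number here means a weaker inhibitor, a lower number a stronger inhibitor), compound 1 gives 17000 nM, the only actual number so far. The result for compound 2, > 25000 nM, is a limit. Compound 3 `Cn1nc(N)c(/N=N/c2ccncc2)c1N` differs from compound 1 by a single change, methyl in place of hydrogen on an aromatic nitrogen. Going by the values given here, no measured pair shows what this change does. The expected step in this assay, a 1.1-fold lower number from compound 1 to compound 3 (0.05 log units; within the scatter), is therefore none beyond the scatter, and no direction is favoured. Compound 3 is estimated at 15000 nM, with an expected range of 6000 nM to 32000 nM.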

Compound 3, half-maximal inhibitory concentration: 67400 nM
Compound 3: middle estimate off by 4.5-fold (0.65 log units), on the low side; measured number outside the range, above it.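

For the compounds shown here, the methyl on the aromatic nitrogen gives the first measured reading of this change: in this assay it brings a 4.0-fold higher number from compound 1 to compound 3 (0.60 log units; beyond the scatter). At this position, then, replacing the hydrogen with methyl weakens the compound rather than leaving it unchanged, though this single pair is all that shows it. Compound 2 is reported only as a limit, so this step sits at the weak end of what the assay reports: the limit of > 25000 nM in this assay, at which 1 of the 3 values shown sits.

As far as these compounds go, whether an ethyl group or a longer chain on that nitrogen would weaken it further remains open. So does the effect of an acetyl group there.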